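The compounds below may be only part of what the source reports. "The series", "measured", "known", "first", "only" and "open" are said of these compounds alone.

Series notes, corticotropin-releasing factor receptor 1 binding.

Compound 1 `CCCCN(C)Cc1c(C(F)(F)F)nc2n(-c3c(C)cc(C)cc3C)c(Cl)cn12` gives 310 nM in an assay on cells for displacement of a labelled ligand from corticotropin-releasing factor receptor 1 (Homo sapiens), with a stated time of 100 min (a higher number here means a weaker inhibitor, a lower number a stronger inhibitor), and stands highest of the three measured numbers; compound 3 `CCCCN(Cc1ccccc1)Cc1c(C(F)(F)F)nc2n(-c3c(C)cc(C)cc3C)c(Cl)cn12` gives 130 nM and compound 2 `Cc1cc(C)c(-n2c(Cl)cn3c(CN(CCC(F)(F)F)Cc4cccc(F)c4)c(C(F)(F)F)nc23)c(C)c1` gives 49 nM. Within the data shown here, the one single-site step, a 2.4-fold lower number from compound 1 to compound 3 (0.38 log units; beyond the scatter), is the only measured change that bears directly on compound 4 `Cc1cc(C)c(-n2c(Cl)cn3c(CN(C)Cc4ccco4)c(C(F)(F)F)nc23)c(C)c1`, which differs from compound 1 by furan-2-yl in place of propyl on a saturated chain carbon bound to an amine nitrogen. Compound 2, with two altered substituents on the amine nitrogen, is not a single-site comparison; its number merely shows that the shared core tolerates varied groups there. An aromatic ring entering on the saturated chain carbon bound to the amine nitrogen lowered the number in the step to compound 3, so a lowering of similar, modest size is expected for compound 4, as a 2.1-fold lower number from compound 1 to compound 4 (0.32 log units; beyond the scatter). Compound 4 is thus estimated at 150 nM, range 60 nM to 400 nM.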

Compound 4, inhibition constant: 180 nM
The estimate for compound 4 lay 1.2-fold (0.08 log units) below the measured number, and the stated range covers the measured number.
By their numbers in this assay, from the lowest: compound 2; then compounds 3, 4 and 1 (each within the scatter of the next, the first and the last beyond it).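

Furan-2-yl in place of propyl on a saturated chain carbon bound to an amine nitrogen gives a 1.7-fold lower number from compound 1 to compound 4 (0.24 log units; within the scatter), so this exchange cannot be told apart from the usual scatter. The earlier compounds shown here showed no aromatic ring with a hetero atom at this place, and here one is tolerated without a resolved change in binding. Nothing available accounts for this result.

The compounds shown leave open how a thiophene or pyridine ring, or a longer chain carrying the furan ring, would read at this place. Also open, on these data alone, is whether furan-2-yl would read the same with butyl instead of methyl on the amine nitrogen.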